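A few compounds are considered here, and "the series" means these few. Any claim that something is new, unique, unknown or untested is made for them only; others in the source may bear on it.

Compound 2 `COc1ccc(C2=NN(C3=NC(=O)/C(=C4\C(=O)Nc5ccccc54)S3)C(c3ccc(OC)cc3)C2)cc1` is the weakest of the three compounds measured in a functional assay on cells (Cancer cell lines, Homo sapiens) for cytotoxicity, read by sulforhodamine B assay, with a stated time of 48 h; a higher number here means a weaker inhibitor of growth, a lower number a stronger inhibitor of growth: compound 2 gives 88100 nM, while compound 1 `COc1ccc(C2CC(c3ccccc3)=NN2C2=NC(=O)/C(=C3\C(=O)Nc4ccccc43)S2)cc1` gives 2380 nM and compound 3 `COc1ccc(C2=NN(C3=NC(=O)/C(=C4\C(=O)Nc5ccc(Br)cc54)S3)C(c3ccc(OC)cc3)C2)cc1` gives 200 nM. The change now followed leads to compound 4 `COc1ccc(C2CC(c3ccc4ccccc4c3)=NN2C2=NC(=O)/C(=C3\C(=O)Nc4ccccc43)S2)cc1`, in which (naphthalen-2-yl in place of 4-methoxyphenyl on a carbon with a double bond to nitrogen). For the measured compounds named here, of the measured steps, only the one from compound 1 to compound 2 touches the same position: there a 37-fold higher number from compound 1 to compound 2 (1.57 log units; beyond the scatter), so a methoxy at that aryl group went with a markedly higher number. The step of a 440-fold lower number from compound 2 to compound 3 (2.64 log units; beyond the scatter) concerns a different part of the molecule and does not bear on this change directly. Since compound 4 carries no methoxy on the entering naphthalen-2-yl group, the step from compound 2 to compound 4 is expected to run in the opposite direction to the step from compound 1 to compound 2, roughly back toward the number seen for compound 1, that is a 29-fold lower number from compound 2 to compound 4 (1.47 log units; beyond the scatter). Compound 4 is therefore expected to give about 3000 nM, plausibly between 500 nM and 20000 nM.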

Compound 4, concentration for 50% growth inhibition: 620 nM
Compound 4: middle estimate off by 4.8-fold (0.68 log units), on the high side, within the range that was stated.
By their numbers in this assay, from the lowest: compound 3; then compound 4; then compound 1; then compound 2.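

In this assay, the position on the carbon with a double bond to nitrogen proves not to be limited to phenyl: replacing phenyl with naphthalen-2-yl gives a modest gain (a 3.8-fold lower number from compound 1 to compound 4 (0.58 log units; beyond the scatter)), while replacing 4-methoxyphenyl with naphthalen-2-yl gives a far larger one (a 140-fold lower number from compound 2 to compound 4 (2.15 log units; beyond the scatter)). Both 4-methoxyphenyl and naphthalen-2-yl extend beyond phenyl, yet they move the number in opposite directions, so among compound 1, compound 2 and compound 4 the number does not simply follow the added atoms. Nothing available explains why these groups differ in this way.

The compounds shown leave open whether a pyridin-3-yl ring or a phenyl carrying a dimethylamino group would be tolerated here. They also leave open whether naphthalen-2-yl and bromo together would lower the number further.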